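A few compounds are considered here, and "the series" means these few. Any claim that something is new, unique, unknown or untested is made for them only; others in the source may bear on it.

Compound 1: `NS(=O)(=O)C1CCN(c2ncc(C(=O)Nc3nc(-c4cccc(C(F)(F)F)c4F)cs3)cc2Cl)CC1`. In a physicochemical assay for solubility (on this read-out lower numbers stand for lower solubility and higher numbers for higher solubility), compound 1 gives < 10 ug/mL, which is a limit of the assay rather than a number.
Compound 2: `O=C(Nc1nc(-c2cccc(C(F)(F)F)c2F)cs1)c1cnc(N2CCNC(C(=O)O)C2)c(Cl)c1`. In this assay compound 2 gives < 10 ug/mL, again a limit.
Compound 3: `O=C(Nc1nc(-c2cccc(C(F)(F)F)c2F)cs1)c1cnc(N2CCCC(C(=O)O)C2)c(Cl)c1`. In this assay compound 3 gives < 10 ug/mL, also a limit.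

Compound 3 therefore stands at the point described by the limit of < 10 ug/mL in this assay, at which 3 of the 3 values shown sit, and nothing in the recorded values sets it apart from compound 1 or compound 2. The steps measured among these three are all of the same unreadable kind: a step that the two limits leave unreadable from compound 1 to compound 3, a step that the two limits leave unreadable from compound 2 to compound 3 and a step that the two limits leave unreadable from compound 1 to compound 2, so none of them gives a size or a direction that could be carried forward.

The unmeasured compound 4 is `O=C(Nc1nc(-c2cccc(C(F)(F)F)c2F)cs1)c1cnc(N2CCC(c3nn[nH]n3)CC2)c(Cl)c1`. It differs from compound 3 by the change (4-(2H-tetrazol-5-yl)piperidin-1-yl in place of 3-carboxypiperidin-1-yl on an aromatic carbon). Going by the values given here, no measured step in this set resembles this exchange, and the steps that do touch compound 3 are unreadable, so there is no basis for expecting a movement beyond the scatter. The account therefore expects compound 4 to remain at or near the same limit in this assay, with the step that the limit leaves unreadable from compound 3 to compound 4 estimated as essentially flat. The estimate for compound 4 is 5 ug/mL, with a range from 1 ug/mL to 15 ug/mL, and most likely the assay will again report only a limit.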

Compound 4, solubility: < 10 ug/mL
Compound 4: a limit, no number; the forecaster's own chance of this, stated with the estimate: 80%; the middle value does not contradict the limit.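

Compound 4 also returns only a limit, so its steps to compound 1, compound 2 and compound 3 cannot be read in this assay, and the set stays without a readable step: the limit of < 10 ug/mL in this assay, at which 4 of the 4 values shown sit.

The compounds shown leave open what number each of the four would have, and whether any of these exchanged groups on the shared core shifts the read-out at all.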